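Swapping methoxy for methylsulfanyl in a cytotoxic enone

A few compounds are considered here, and "the series" means these few. Any claim that something is new, unique, unknown or untested is made for them only; others in the source may bear on it.

Compound 1 `COc1cc(OC)c(C(=O)/C=C/c2ccccc2SC)c(OC)c1` gives 9300 nM
Compound 2 `COc1cc(O)c(C(=O)/C=C/c2ccccc2OC)c(OC)c1` gives 10500 nM

In a functional assay on MCF7 cells (Homo sapiens) for cytotoxicity, with a stated time of 48 h (on this read-out lower numbers stand for stronger inhibition and higher numbers for weaker inhibition), compound 2 stands at 10500 nM, within the scatter of compound 1 at 9300 nM. Compound 3 `COc1cc(O)c(C(=O)/C=C/c2ccccc2SC)c(OC)c1` differs from compound 2 in one place, with methylsulfanyl in place of methoxy on an aromatic carbon, ortho to a large group (methylsulfanyl in place of methoxy on an aromatic carbon). Within the data shown here, no measured pair shows this change alone. Compound 1, which also carries methylsulfanyl, gives 9300 nM, so no step beyond the scatter is expected in this assay. The estimated change is a 1.2-fold lower number from compound 2 to compound 3 (0.07 log units; within the scatter), with no firm direction expected. For compound 3 the expected value is 9000 nM, with an estimated range of 3500 nM to 20000 nM.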

Compound 3, half-maximal inhibitory concentration: 15900 nM
The estimate for compound 3 lay 1.8-fold (0.25 log units) below the measured number, within the range that was stated.
By their numbers in this assay, from the lowest: compounds 1, 2 and 3 (each within the scatter of the next).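

With a 1.5-fold higher number from compound 2 to compound 3 (0.18 log units; within the scatter) in this assay, methylsulfanyl in place of methoxy on an aromatic carbon, ortho to a large group, now has a measured step of its own, and that step lies within the scatter. Hydrogen in place of methyl on an oxygen on an aromatic ring gives a 1.7-fold higher number from compound 1 to compound 3 (0.23 log units; within the scatter), also within the scatter. No measurement shown explains either step. The compounds shown leave open whether an amine or a longer chain such as ethylsulfanyl on that aromatic carbon would give a step beyond the scatter.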